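Removing the amide hydrogen on the pyrazole carboxamide series

The source may hold more compounds than are shown below. What is called first, only, known or untested is meant among the compounds shown, and "the series" means these compounds.

Measured so far: compound 1 `CC(C)c1c(C(=O)NCc2ccccn2)nn(-c2ccc(F)cc2)c1OC[C@@H](O)C[C@@H](O)CC(=O)O`, 25 nM; compound 2 `COc1ccccc1CNC(=O)c1nn(-c2ccc(F)cc2)c(OC[C@@H](O)C[C@@H](O)CC(=O)O)c1C(C)C`, 22 nM.

In an assay on microsomes from liver for inhibition of 3-hydroxy-3-methylglutaryl-coenzyme A reductase (Rattus norvegicus) (a lower number here means a stronger inhibitor, a higher number a weaker inhibitor), compound 2 gives the lowest of the two numbers, and compound 1 stands nearest with a step of a 1.1-fold lower number from compound 1 to compound 2 (0.06 log units; within the scatter). Compound 3 `CC(C)c1c(C(=O)N(C)Cc2ccc(F)c(F)c2)nn(-c2ccc(F)cc2)c1OC[C@@H](O)C[C@@H](O)CC(=O)O` differs from compound 2 by (3,4-difluorobenzyl)(methyl)amino in place of (2-methoxybenzyl)amino on a carbonyl carbon. Among the measured compounds shown here, only the step from compound 1 to compound 2 bears on this change, and it shows that swapping the ring on the saturated carbon left this assay unchanged. For the measured compounds named here, no measured step covers the loss of the hydrogen-bond donor, so a modest weakening is expected, with the step of a 2.0-fold higher number from compound 2 to compound 3 (0.31 log units; beyond the scatter), giving compound 3 an estimated 45 nM in a range of 12 nM to 170 nM.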

Compound 3, half-maximal inhibitory concentration: 5.7 nM
For compound 3 the middle estimate is 7.9-fold (0.90 log units) above the measured one; the whole stated range lies above it.
By their numbers in this assay, from the lowest: compound 3; then compounds 2 and 1 (each within the scatter of the next).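

At the carbonyl carbon, this assay moved with this change: it gave a 3.9-fold lower number from compound 2 to compound 3 (0.59 log units; beyond the scatter) and a 4.4-fold lower number from compound 1 to compound 3 (0.64 log units; beyond the scatter), whereas the earlier ring swap stayed within the scatter. The amide hydrogen is therefore not required for a low number in compound 3, which has no hydrogen-bond donor in this group. Nothing measured here explains the step. The compounds shown leave open how much of the step belongs to the methyl on the nitrogen and how much to the 3,4-difluorobenzyl group, as both changed together. They also leave open whether an ethyl group on that nitrogen would give a similar number.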